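The source may hold more compounds than are shown below. What is called first, only, known or untested is meant among the compounds shown, and "the series" means these compounds.

Compound 2, with the structure `CS(=O)(=O)c1ccc(C(=O)Nc2ccc(Cl)c(-c3nnc4c(Cl)cccn34)c2)cc1`, reaches in a functional assay on AN3-CA cells (Homo sapiens) for antiproliferative activity, read by MTT assay, with a stated time of 72 h (a lower number here means a stronger inhibitor, a higher number a weaker inhibitor), only a limit, > 100000 nM. Compound 1, `O=C(Nc1ccc(Cl)c(-c2nnc3c(Cl)cccn23)c1)c1cccc(Cl)c1`, gives 68400 nM in this assay, and the step of an at least 1.4-fold higher number from compound 1 to compound 2 (0.16 log units; that floor lies within the scatter) marks the move to 4-(methylsulfonyl)phenyl. Compound 3, `CS(=O)(=O)c1ccc(C(=O)Nc2ccc(Cl)c(-c3nnc4c(Cl)cccn34)c2)c(Cl)c1`, likewise shows only a limit, > 100000 nM. The step that the two limits leave unreadable from compound 2 to compound 3 stays unreadable because of the limit of > 100000 nM in this assay, at which 2 of the 3 values shown sit. Compound 4, `O=C(Nc1ccc(Cl)c(-c2nnc3c(Cl)cccn23)c1)c1cccnc1Cl`, differs from compound 2 in 2-chloropyridin-3-yl in place of 4-(methylsulfonyl)phenyl on a carbonyl carbon. Among the measured compounds shown here, compound 2 stands at a limit, so no sized step leads from it; the only readable step, an at least 1.4-fold higher number from compound 1 to compound 2 (0.16 log units; that floor lies within the scatter), lies within the scatter, and compound 1 with its 3-chlorophenyl offers the nearest measured point. Compound 4 is therefore expected in this assay to give 80000 nM, within 30000 nM to 250000 nM. The expected step is an at least 1.2-fold lower number from compound 2 to compound 4 (0.09 log units; that floor lies within the scatter).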

Compound 4, half-maximal inhibitory concentration: > 100000 nM
Compound 4 was reported as a limit; the forecaster's own chance of this, stated with the estimate: 45%; at least 1.2-fold (0.09 log units) between middle value and limit.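

Putting a ring with a hetero atom on the carbonyl carbon, 2-chloropyridin-3-yl in place of 3-chlorophenyl, gives in this assay an at least 1.4-fold higher number from compound 1 to compound 4 (0.16 log units; that floor lies within the scatter). So a chlorine-bearing pyridine offers no measurable gain over compound 1, and compound 1 remains the only one of the four with a value that is not a limit. The step from compound 2 to compound 4 cannot be read, because both values are the same limit: the limit of > 100000 nM in this assay, at which 3 of the 4 values shown sit.

From the compounds shown here alone, it remains open whether any group at this place brings the value clearly under that limit, for example a phenyl ring carrying an amine or a carboxylic acid.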